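The compounds below may be only part of what the source reports. "The series", "measured", "known", "first", "only" and "open" are said of these compounds alone.

Measured so far:
compound 1, `Nc1scc(CN2CCN(c3ccc([N+](=O)[O-])cc3)CC2)c1C(=O)c1ccc(Cl)cc1`, -8.3%
compound 2, `Nc1scc(CN2CCN(c3c(F)cccc3F)CC2)c1C(=O)c1cccc(C(F)(F)F)c1`, 1.3%

In a functional assay on CHO cells with adenosine receptor A1 (Homo sapiens) as the target, read by cAMP accumulation and immunoassay, with a stated time of 6 min, tested at 1 uM (a lower number here means a stronger effect, a higher number a weaker effect of the compound at the concentration tested), compound 1 gives -8.3%. Compound 2 gives 1.3% in this assay, and the two numbers lie within the usual scatter of each other, so neither stands apart from the other. Compound 3, `Nc1scc(CN2CCN(c3cc(F)ccc3F)CC2)c1C(=O)c1ccc(Cl)cc1`, has not been measured yet. It differs from compound 1 in one place: 2,5-difluorophenyl in place of 4-nitrophenyl on an amine nitrogen in a ring. Going by the values given here, no measured pair shows what such a change does here, so the change is expected to bring nothing beyond the scatter, with a step of a number 6.3 percentage points higher from compound 1 to compound 3 (within the scatter) expected. Compound 3 is therefore estimated to give -2% in this assay, within a range from -14% to 10%.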

Compound 3, a percentage reported as activity, at one concentration (the size of the read-out at that concentration, not a potency): -59%
The estimate for compound 3 lay 57 percentage points above the measured number; the measured number lies below the stated range.
By their numbers in this assay, from the lowest: compound 3; then compounds 1 and 2 (each within the scatter of the next).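

In this assay, the group on the amine nitrogen of the six-membered ring clearly matters: 2,5-difluorophenyl in place of 4-nitrophenyl gives a number 50.7 percentage points lower from compound 1 to compound 3 (beyond the scatter), a large step. Compounds 1 and 2 differ in more than one place, so they could not isolate this position. Nothing measured here bears on the reason for this step.

Going by these compounds, it remains open whether an unsubstituted phenyl or a methoxyphenyl in this place would give a similar number. It is also unknown whether the step keeps its size when the rest of the molecule changes.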